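Chalcone-aminoquinoline hybrids: Vero cell tolerability notes

The source may report more compounds than this note shows. Statements on the series, on what has been measured and on what is new or still open speak of the compounds shown alone.

Measured compounds in an ADME assay on Vero cells (Chlorocebus sabaeus) for cytotoxicity, read by MTT assay, with a stated time of 72 h; a higher number here means that more compound is tolerated, a lower number that less compound is tolerated:
compound 1 `COc1ccc(/C=C/C(=O)c2ccc(OCC(O)CNCCNc3ccnc4cc(Cl)ccc34)cc2)cc1OC` gives 10200 nM
compound 2 `COc1cc(OC)c(OC)cc1/C=C/C(=O)c1ccccc1OCC(=O)NCCNc1ccnc2cc(Cl)ccc12` gives 12300 nM
compound 3 `COc1ccc(/C=C/C(=O)c2ccccc2OCC(=O)NCCNc2ccnc3cc(Cl)ccc23)cc1OC` gives 5310 nM

For the measured compounds named here, the one step between measured compounds differing in a single place is a 2.3-fold higher number from compound 3 to compound 2 (0.36 log units; beyond the scatter), the change being (methoxy in place of hydrogen on an aromatic carbon). Compound 1 and compound 3 share no single-point relation; the difference between the two cores is not broken down here.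

Compound 4 `COc1cc(/C=C/C(=O)c2ccc(OCC(O)CNCCNc3ccnc4cc(Cl)ccc34)cc2)cc(OC)c1OC` is not yet measured in this assay. It differs from compound 1 by methoxy in place of hydrogen on an aromatic carbon. This is the same kind of change as that from compound 3 to compound 2, not the same: in compound 2 the entering methoxy sits ortho to a large group, meta to a methoxy group and para to a methoxy group, whereas in compound 4 it sits ortho to a methoxy group, meta to a large group and meta to a methoxy group, and the cores differ as said. Resting on the step from compound 3 to compound 2 being a 2.3-fold higher number from compound 3 to compound 2 (0.36 log units; beyond the scatter) and on compound 1 giving 10200 nM, the expected step is a 1.6-fold higher number from compound 1 to compound 4 (0.20 log units; within the scatter). Compound 4 is estimated at 16000 nM, expected within 7000 nM to 35000 nM.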

Compound 4, half-maximal cytotoxic concentration: 1910 nM
For compound 4 the middle estimate is 8.4-fold (0.92 log units) above the measured one, outside the stated range (below it).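

In this assay, going from 3,4-dimethoxyphenyl to 3,4,5-trimethoxyphenyl gives a 5.3-fold lower number from compound 1 to compound 4 (0.73 log units; beyond the scatter), so the gain seen on the other core does not carry over, and the direction of this change cannot be assumed from one core to the other: the same change on two cores in this assay, a 2.3-fold higher number (0.36 log units; beyond the scatter) from compound 3 to compound 2 and a 5.3-fold lower number (0.73 log units; beyond the scatter) from compound 1 to compound 4, 12-fold (1.09 log units) apart, beyond the scatter of two such steps

The entering methoxy also sits in a different place in each pair, and the cores differ as well. For the compounds shown here, with only two pairs, the data do not show whether place, core or both set the outcome, and they give no general rule for the series.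

Still open, from the compounds shown here alone, is how the same change behaves when placed identically on both cores. Also open, going by these compounds, is whether ethoxy or fluorine on that aromatic carbon would follow the methoxy result.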